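The compounds below may be only part of what the source reports. "The series", "measured", "known", "first", "only" and "open" are said of these compounds alone.

Compound 3, `Cn1ncc2c(NC(=O)NCc3cc(C(C)(C)C)nn3-c3ccc(F)c(F)c3)cccc21`, holds the lowest of the three numbers in an assay on CHO-K1 cells for antagonist activity at transient receptor potential cation channel subfamily V member 1 (Homo sapiens), read by FLIPR and calcium flux, with a stated time of 6 min (a lower number here means a stronger inhibitor, a higher number a weaker inhibitor), where compound 3 gives 1 nM. Compound 2, `Cn1ncc2c(NC(=O)NCc3cc(C(C)(C)C)nn3-c3ccc(F)cc3)cccc21`, gives 4.5 nM, and compound 1, `Cn1ncc2c(NC(=O)NCc3cc(C(C)(C)C)nn3-c3ccc(Cl)cc3)cccc21`, gives 9.5 nM; the steps of a 4.5-fold lower number from compound 2 to compound 3 (0.65 log units; beyond the scatter) and a 9.5-fold lower number from compound 1 to compound 3 (0.98 log units; beyond the scatter) both lie beyond the scatter. Compound 4, `Cn1ncc2c(NC(=O)NCc3cc(C(C)(C)C)nn3-c3ccc(F)c(Cl)c3)cccc21`, differs from compound 3 by a single change: chloro in place of fluoro on an aromatic carbon. Among the measured compounds shown here, the one measured step that bears directly on exchanging these two halogens is a 2.1-fold lower number from compound 1 to compound 2 (0.32 log units; beyond the scatter), in which fluoro in place of chloro lowered the number by a modest amount. Read in the reverse direction, chloro in place of fluoro would be expected to raise the number by a comparable, modest amount, though this rests on a single pair. The step expected in this assay is therefore a 2.0-fold higher number from compound 3 to compound 4 (0.30 log units; within the scatter), a small loss that may still sit close to the scatter. Compound 4 is estimated at 2 nM in this assay, with a likely range from 0.7 nM to 6 nM.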

Compound 4, inhibition constant: 0.6 nM
Compound 4: the middle estimate sits 3.3-fold (0.52 log units) above what was measured; the measured number lies below the stated range.
By their numbers in this assay, from the lowest: compounds 4 and 3 (each within the scatter of the next); then compound 2; then compound 1.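

In this assay, the exchange at this carbon, ortho to a fluoro group, gives a 1.7-fold lower number from compound 3 to compound 4 (0.22 log units; within the scatter), so at this position the data do not separate chloro from fluoro. Chloro in place of hydrogen gives a 7.5-fold lower number from compound 2 to compound 4 (0.88 log units; beyond the scatter), and 3-chloro-4-fluorophenyl in place of 4-chlorophenyl gives a 16-fold lower number from compound 1 to compound 4 (1.20 log units; beyond the scatter), which shows that this carbon takes chloro as well as fluoro with a number well under those of the compounds lacking a halogen there. The exchange between the two halogens therefore does not carry over from the earlier pair to this one: the same change on two cores in this assay, a 2.1-fold lower number (0.32 log units; beyond the scatter) from compound 1 to compound 2 and a 1.7-fold higher number (0.22 log units; within the scatter) from compound 4 to compound 3, 3.5-fold (0.55 log units) apart, beyond the scatter of two such steps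

From the compounds shown here alone, whether methyl, trifluoromethyl or a nitrile at this carbon would keep the number as low remains open. So does how much of the chloro step depends on the fluoro group ortho to it.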